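The source may report more compounds than this note shows. Statements on the series, on what has been measured and on what is new or still open speak of the compounds shown alone.

Measured in a functional assay on SK-OV-3 cells (Homo sapiens) for inhibition, read by CCK-8 assay, with a stated time of 70 h; a higher number here means a weaker inhibitor, a lower number a stronger inhibitor:
- compound 1 `c1ccc(COc2ccc(OCCOCCNC3CCCC3)cc2)cc1`: 24800 nM
- compound 2 `c1ccc(COc2ccc(OCCOCCNC3CCOC3)cc2)cc1`: 48000 nM

These two values lie within the scatter of each other, so compound 1 cannot be ranked against compound 2. Compound 3 `c1ncn(-c2ccc(OCCOCCNC3CCCC3)cc2)n1` keeps the rest of compound 1 but carries 1H-1,2,4-triazol-1-yl in place of benzyloxy on an aromatic carbon. Among the measured compounds shown here, the only measured step, a 1.9-fold higher number from compound 1 to compound 2 (0.29 log units; within the scatter), puts oxolan-3-yl in place of cyclopentyl on an amine nitrogen and leaves the benzyloxy untouched. For the measured compounds named here, it bears only weakly on this change, and no measured compound varies that group. No step beyond the scatter can therefore be expected in this assay in either direction, though the uncertainty is wide. The expected step is a 1.6-fold higher number from compound 1 to compound 3 (0.21 log units; within the scatter). The estimated value for compound 3 is 40000 nM, with an expected range of 12000 nM to 120000 nM.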

Compound 3, half-maximal inhibitory concentration: > 100000 nM
Compound 3 gave a limit, no number; the forecaster's own chance of this, stated with the estimate: 25%; middle value at least 2.5-fold (0.39 log units) away from the limit.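

In this assay, compound 3 gives > 100000 nM, which is a limit of the assay and not a number. Exchanging benzyloxy for 1H-1,2,4-triazol-1-yl on the aromatic carbon gives an at least 4.0-fold higher number from compound 1 to compound 3 (0.60 log units; beyond the scatter), whereas the change on the amine nitrogen gave only a 1.9-fold higher number from compound 1 to compound 2 (0.29 log units; within the scatter), so this aromatic position is the first shown where a single change moves the number beyond the scatter, towards a weaker inhibitor. The true size of that step remains bounded from one side only: the limit of > 100000 nM in this assay, at which 1 of the 3 values shown sits.

The compounds shown leave open whether the weakening follows from losing the benzyloxy group or from the triazole ring that replaces it. A plain phenyl, a methoxy or an imidazol-1-yl group at this position would help to separate these two readings.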